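Replacing Hydroxy with Nitro on a Shared Core

The source may hold more compounds than are shown below. What is called first, only, known or untested is meant among the compounds shown, and "the series" means these compounds.

Of the compounds shown here, three built on one shared core have been tested in a functional assay on the whole organism with Mus musculus as the target, in the maximal electroshock model, with a stated time of 0.5 h; a higher number here means that more compound is needed for the effect, a lower number that less compound is needed. Compound 1 `O=C(N/N=C/c1ccccc1Cl)Nc1ccc(Br)cc1` gives 300 mg/kg. Compound 2 `O=C(N/N=C/c1ccccc1[N+](=O)[O-])Nc1ccc(Br)cc1`, which carries a nitro in place of chloro on an aromatic carbon, gives 300 mg/kg, and the step of no change at the digits printed from compound 1 to compound 2 (within the scatter) shows no change. Compound 3 `C/C(=N\NC(=O)Nc1ccc(Br)cc1)c1ccc(O)cc1` gives 300 mg/kg, level with compounds 1 and 2; the three values lie within the ordinary scatter of this kind of measurement, so none of these compounds can be called more or less active than another.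

The new compound, compound 4 `C/C(=N\NC(=O)Nc1ccc(Br)cc1)c1ccc([N+](=O)[O-])cc1`, differs from compound 3 in one place: nitro in place of hydroxy on an aromatic carbon. Going by the values given here, the one measured step that bears on this, no change at the digits printed from compound 1 to compound 2 (within the scatter), also brought a nitro group onto an aromatic carbon and stayed within the scatter. Nothing in the measured set points to a nitro group moving the minimum effective dose in either direction.

For compound 4 the expected step is therefore no change at the digits printed from compound 3 to compound 4 (within the scatter), none beyond the scatter. Compound 4 is estimated to give 300 mg/kg in this assay, with a likely range from 100 mg/kg to 600 mg/kg.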

Compound 4, minimum effective dose: 300 mg/kg
The estimate for compound 4 equals the measured number at the digits printed, and the stated range covers the measured number.
By their numbers in this assay, from the lowest: compounds 1, 2, 3 and 4 (each within the scatter of the next).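

In this assay, the exchange of hydroxy for nitro on an aromatic carbon para to a large group gives no change at the digits printed from compound 3 to compound 4 (within the scatter), so this place on the ring accepts the change without a visible effect on the minimum effective dose. The earlier step only exchanged chloro for nitro, whereas this one removes a group with a hydrogen-bond donor and puts in a larger group of 3 heavy atoms with 0 hydrogen-bond donors and 2 hydrogen-bond acceptors, and the read-out still stays within the scatter. Nothing measured here offers an explanation of this result, so it stands as an observation only.

All four compounds now sit level in this assay, which means the compounds shown do not reveal any change on this ring that moves the dose in either direction. Going by these compounds, whether an amine, a carboxylic acid or a longer chain on this same aromatic carbon would shift the minimum effective dose, and whether hydroxy and nitro would also match on a different core, remains open.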